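The source may hold more compounds than are shown below. What is called first, only, known or untested is meant among the compounds shown, and "the series" means these compounds.

Compound 1 `Cc1cc(OC(=O)OCCCCCCO[N+](=O)[O-])n(-c2ccccc2)n1`: 4 h
Compound 2 `Cc1cc(OC(=O)C(C)(C)CO[N+](=O)[O-])n(-c2ccccc2)n1`: 1.9 h
Compound 3 `Cc1cc(OC(=O)C(C)(C)CCCCO[N+](=O)[O-])n(-c2ccccc2)n1`: 24 h

These three were measured in a physicochemical assay for metabolic stability, read by HPLC; a higher number here means that the compound lasts longer, a lower number that the compound disappears faster. Compound 1 and compound 3 have different cores; that difference is not broken down here. Compound 3 and compound 2 differ in one place: nitrooxy in place of 3-(nitrooxy)propyl on a saturated chain carbon, two bonds along the chain from a carbonyl carbon. That change gave a 13-fold lower number from compound 3 to compound 2 (1.10 log units; beyond the scatter).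

Compound 4 `Cc1cc(OC(=O)OCCCO[N+](=O)[O-])n(-c2ccccc2)n1` has not yet been measured. It differs from compound 1 by nitrooxy in place of 3-(nitrooxy)propyl on a saturated chain carbon, three bonds along the chain from an oxygen next to a carbonyl group. This is the same kind of change as from compound 3 to compound 2, not the same one: there the place was a saturated chain carbon two bonds along the chain from a carbonyl carbon, here it is three bonds along the chain from an oxygen next to a carbonyl group.

Because a 13-fold lower number from compound 3 to compound 2 (1.10 log units; beyond the scatter) was large, a drop of similar direction is expected for compound 4, giving an 8.0-fold lower number from compound 1 to compound 4 (0.90 log units; beyond the scatter). The estimate for compound 4 in this assay is 0.5 h, expected to lie between 0.2 h and 1.5 h.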

Compound 4, half-life: 1.4 h
Beside the measured number, compound 4's estimate is 2.8-fold (0.45 log units) below it; measured number inside the range.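

In this assay the same kind of change lowered the number on both cores, giving a 13-fold lower number from compound 3 to compound 2 (1.10 log units; beyond the scatter) and a 2.9-fold lower number from compound 1 to compound 4 (0.46 log units; beyond the scatter). So the direction carried over from one core to the other, while the size did not stay the same: the first step is large and the second modest, and with one pair per core and a different place in the chain for each, this makes no general rule. No measurement here explains either drop.

Going by these compounds, it remains open how a carboxylic acid in place of the nitrooxy group would behave on either core. Among the compounds shown here, also open is whether a longer chain than the one in compound 1 would change the number.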